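A few compounds are considered here, and "the series" means these few. Any claim that something is new, unique, unknown or untested is made for them only; others in the source may bear on it.

Measured so far:
compound 1, `NC(=O)c1c(NC(=O)c2ccccc2Cl)sc2c1CCN(Cc1ccccc1F)C2`: > 50000 nM
compound 2, `COc1ccc(NC(=S)N2CCc3c(sc(NC(=O)c4ccccc4Cl)c3C(N)=O)C2)cc1`: 36400 nM

In a functional assay on HeLa cells (Homo sapiens) for antiproliferative activity, with a stated time of 24 h (a lower number here means a stronger inhibitor, a higher number a weaker inhibitor), compound 1 gives only a limit, > 50000 nM. Among the measured compounds shown here, compound 2 gives 36400 nM, the sole number in the set. The other entry, that of compound 1, is a limit (the limit of > 50000 nM in this assay, at which 1 of the 2 values shown sits). The step of an at least 1.3-fold lower number from compound 1 to compound 2 (0.13 log units; that floor lies within the scatter) concerns a change on an amine nitrogen in a ring, and its floor lies within the scatter. Compound 3, `NC(=O)c1c(NC(=O)c2ccccc2Cl)sc2c1CCN(C(=S)Nc1cccnc1)C2`, carries pyridin-3-yl in place of 4-methoxyphenyl on an amide-type nitrogen. For the measured compounds named here, no measured step touches that position, so nothing beyond the scatter is expected for a 1.1-fold higher number from compound 2 to compound 3 (0.04 log units; within the scatter). Compound 3 is therefore estimated at 40000 nM, within a range of 15000 nM to 120000 nM.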

Compound 3, half-maximal inhibitory concentration: > 50000 nM
Compound 3 ended at the assay's limit (the forecaster's own chance of this, stated with the estimate: 45%); middle value at least 1.2-fold (0.09 log units) from the limit.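

In this assay, among the compounds shown here, pyridin-3-yl in place of 4-methoxyphenyl on the amide-type nitrogen gives the first reading at this position, an at least 1.3-fold higher number from compound 2 to compound 3 (0.13 log units; that floor lies within the scatter). Compound 3 gives only a limit, > 50000 nM. The step between compound 1 and compound 3 cannot be read, as both values are limits, and the set now gathers at that limit: the limit of > 50000 nM in this assay, at which 2 of the 3 values shown sit.

For the compounds shown here, compound 2 remains the only compound with a number. Still open, as far as these compounds go, is whether another group on this nitrogen, such as 4-chlorophenyl or a longer alkyl chain, gives a number beyond the scatter from compound 2.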